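A Hexylsulfanyl Replacement Examined for Cytotoxicity

The source may report more compounds than this note shows. Statements on the series, on what has been measured and on what is new or still open speak of the compounds shown alone.

Compound 1 `Nc1nc(OCc2ccccc2)c2ncn(/C=C3/CC3(CO)CO)c2n1`, compound 2 `Nc1nc(NCc2ccccc2)c2ncn(/C=C3/CC3(CO)CO)c2n1` and compound 3 `Nc1nc2c(ncn2/C=C2/CC2(CO)CO)c(=O)[nH]1` share one core and are all held back by the same ceiling. In an ADME assay on HFF cells (Homo sapiens) for cytotoxicity, with a stated time of 8 days (on this read-out lower numbers stand for higher toxicity in this test and higher numbers for lower toxicity in this test), compound 1 gives > 300000 nM, a limit of the test rather than a number. In this assay compound 2 gives > 300000 nM, which is likewise a limit. In this assay compound 3 gives > 300000 nM, again a limit. Among the measured compounds shown here, the one step between measured compounds, a step that the two limits leave unreadable from compound 1 to compound 2, cannot be sized because of the limit of > 300000 nM in this assay, at which 3 of the 3 values shown sit. Compound 2 therefore stands at the limit with no number to set it apart from the others.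

Compound 4 `CCCCCCSc1nc(N)nc2c1ncn2/C=C1/CC1(CO)CO` has not yet been measured; it differs from compound 2 by hexylsulfanyl in place of benzylamino on an aromatic carbon. For the measured compounds named here, the only step touching this position is the unreadable one from compound 1 to compound 2, so no direction beyond the scatter can be inferred. Compound 4 is expected to show a step of a number no higher from compound 2 to compound 4 (the limit leaves the size open), essentially none. Compound 4 is estimated at 300000 nM, within 100000 nM to 900000 nM, most likely reported again as a limit.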

Compound 4, half-maximal cytotoxic concentration: > 300000 nM
Compound 4 gave a limit, no number; the forecaster's own chance of this, stated with the estimate: 65%; the middle value lies on the limit itself.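

No new step can be read from compound 2 or compound 1 to compound 4, since all of them sit at one ceiling: the limit of > 300000 nM in this assay, at which 4 of the 4 values shown sit. The compounds shown leave open whether any replacement at this aromatic carbon of the shared core would give a readable value in this assay.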